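Acetylation of a Hydroxy Group on Two Related Cores

The source may hold more compounds than are shown below. What is called first, only, known or untested is meant among the compounds shown, and "the series" means these compounds.

Of the compounds shown here, three of this set have been tested in a functional assay on Doay cells (Homo sapiens) for cytotoxicity; on this read-out lower numbers stand for stronger inhibition and higher numbers for weaker inhibition. Compound 1 `C=C1C(=O)O[C@]2(C)CC[C@@H]1C[C@H](O)[C@@]1(C)CC[C@H](O1)[C@](C)(O)CC[C@H]2OC(C)=O` gives in this assay > 20 ug/mL, a limit of the assay rather than a number. Compound 2 `C=C1C(=O)O[C@]2(C)CC[C@@H]1C[C@H](OC(C)=O)[C@@]1(C)CC[C@H](O1)[C@](C)(O)CC[C@H]2OC(C)=O` differs from compound 1 by acetyl in place of hydrogen on an oxygen on a saturated carbon. In this assay compound 2 gives > 20 ug/mL, again only a limit. Between the two lies a step that the two limits leave unreadable from compound 1 to compound 2. Compound 3 `C=C1C(=O)O[C@]2(C)CC[C@@H]1C[C@H](O)[C@@]1(C)CC[C@H](O1)[C@](C)(O)CCC2=O` carries a different core, and how its core differs from that of compound 1 is not broken down here. In this assay compound 3 gives > 20 ug/mL, once more a limit. All three results are summed up in the limit of > 20 ug/mL in this assay, at which 3 of the 3 values shown sit.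

Compound 4 `C=C1C(=O)O[C@]2(C)CC[C@@H]1C[C@H](OC(C)=O)[C@@]1(C)CC[C@H](O1)[C@](C)(O)CCC2=O` is not yet measured and differs from compound 3 by acetyl in place of hydrogen on an oxygen on a saturated carbon, the same change as from compound 1 to compound 2, at a place described in identical words. In this assay compound 4 is expected to give 30 ug/mL, estimated between 15 ug/mL and 100 ug/mL. The expected step that the limit leaves unreadable from compound 3 to compound 4 rests on the limit of > 20 ug/mL in this assay, at which 3 of the 3 values shown sit, and on a step that the two limits leave unreadable from compound 1 to compound 2, which yields no readable size. A limit is the most probable outcome.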

Compound 4, half-maximal inhibitory concentration: > 20 ug/mL
Compound 4 was reported as a limit (the forecaster's own chance of this, stated with the estimate: 85%); the middle value does not contradict the limit.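

In this assay compound 4 gives > 20 ug/mL, a limit of the assay and not a number. For the compounds shown here, compound 3 also stands at a limit, so no step from compound 3 to compound 4 can be read. The compounds shown leave open how strongly any of them acts in this read-out, and whether hydroxy to acetoxy changes it on either core, because every result sits at the same limit: the limit of > 20 ug/mL in this assay, at which 4 of the 4 values shown sit.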